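A few compounds are considered here, and "the series" means these few. Any claim that something is new, unique, unknown or untested is made for them only; others in the source may bear on it.

Of the compounds shown here, three built on one shared core have been tested in a functional assay on HepG2 cells (Homo sapiens) for inhibition, read by MTT assay, with a stated time of 3 days; on this read-out higher numbers stand for weaker inhibition and lower numbers for stronger inhibition. Compound 1 `COc1cc(-c2nc3ccccc3s2)ccc1OCC(=O)NNC(=O)CN[C@@H](CS)C(=O)O` gives 3120 nM in this assay. Compound 2 `COc1cc(-c2nc3ccccc3s2)ccc1OCC(=O)NNC(=O)CN[C@@H](CS(=O)(=O)O)C(=O)O` gives 3690 nM in this assay, the highest of the three numbers, though its gap to each of the other two lies within the scatter. Compound 3 `COc1cc(-c2nc3ccccc3s2)ccc1OCC(=O)NNC(=O)CNC(=N)NCCC[C@H](N[N+](=O)[O-])C(=O)O` gives 3490 nM in this assay. Going by the values given here, the only measured step, a 1.2-fold higher number from compound 1 to compound 2 (0.07 log units; within the scatter), stayed within the scatter. Compound 4 `CCOC(=O)[C@H](CS)NCC(=O)NNC(=O)COc1ccc(-c2nc3ccccc3s2)cc1OC` differs from compound 2 in that (1-(ethoxycarbonyl)-2-sulfanylethyl in place of 1-carboxy-2-sulfoethyl on an amine nitrogen). Here sulfo returns to sulfanyl, which the measured step covers, while carboxy becomes ethoxycarbonyl, for which no measured step exists. Compound 4 is therefore expected to stay near compound 2, with a step of a 1.2-fold lower number from compound 2 to compound 4 (0.09 log units; within the scatter) no larger than the scatter, and an estimated 3000 nM ranging from 1500 nM to 6000 nM.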

Compound 4, half-maximal inhibitory concentration: 3760 nM
The estimate for compound 4 lay 1.3-fold (0.10 log units) below the measured number; low and high end bracket the measured number.
By their numbers in this assay, from the lowest: compounds 1, 3, 2 and 4 (each within the scatter of the next).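

In this assay, the exchange of 1-carboxy-2-sulfoethyl for 1-(ethoxycarbonyl)-2-sulfanylethyl on the amine nitrogen gave a 1.0-fold higher number from compound 2 to compound 4 (0.01 log units; within the scatter) and so did not shift the read-out beyond the scatter. Ethyl in place of hydrogen on an oxygen next to a carbonyl group, a change the earlier compounds did not cover, gave a 1.2-fold higher number from compound 1 to compound 4 (0.08 log units; within the scatter) and so also stayed within the scatter. No evidence is at hand that bears on this result. The compounds shown leave open whether a primary amide or a benzyl ester in place of the ethyl ester would give a step beyond the scatter.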